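A few compounds are considered here, and "the series" means these few. Any claim that something is new, unique, unknown or untested is made for them only; others in the source may bear on it.

For the measured compounds named here, in a toxicity assay on THP-1 cells (Homo sapiens) for cytotoxicity, read by luminescence and CellTiter-Glo, with a stated time of 72 h (a higher number here means that more compound is tolerated, a lower number that less compound is tolerated), compound 1 (`Cc1ccc(-c2ccnc(Nc3ccc(N4CCN(C)CC4)c(C(F)(F)F)c3)n2)cc1`) gives 4940 nM and compound 2 (`CN1CCN(c2ccc(Nc3nccc(-c4ccc5ccccc5c4)n3)cc2C(F)(F)F)CC1`) gives 3040 nM as the only other measured value, and the two lie within the scatter of each other. Compound 3 (`CN1CCN(c2ccc(Nc3nccc(-c4cccnc4)n3)cc2C(F)(F)F)CC1`) has not yet been measured. It carries pyridin-3-yl in place of 4-methylphenyl on an aromatic carbon of the core of compound 1 (pyridin-3-yl in place of 4-methylphenyl on an aromatic carbon) and is otherwise the same. Going by the values given here, the one measured step at this place is a 1.6-fold lower number from compound 1 to compound 2 (0.21 log units; within the scatter) with naphthalen-2-yl in place of 4-methylphenyl, and on that single step no shift beyond the scatter is expected in this assay in either direction. Among the compounds with values here, no measured compound carries pyridin-3-yl, so this expectation remains loose. An estimated 1.1-fold higher number from compound 1 to compound 3 (0.05 log units; within the scatter) is the expected outcome. Compound 3 is estimated at 5500 nM with an expected range from 2500 nM to 12000 nM in this measurement.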

Compound 3, half-maximal cytotoxic concentration: 1060 nM
Beside the measured number, compound 3's estimate is 5.2-fold (0.72 log units) above it; the whole stated range lies above it.
By their numbers in this assay, from the lowest: compound 3; then compounds 2 and 1 (each within the scatter of the next).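

The earlier pair suggested that this position was indifferent to the aryl group, but in this assay pyridin-3-yl moves the number beyond the scatter (a 4.7-fold lower number from compound 1 to compound 3 (0.67 log units; beyond the scatter)) and (a 2.9-fold lower number from compound 2 to compound 3 (0.46 log units; beyond the scatter)). For the compounds shown here, the position on the shared core therefore does respond to what it carries: the two carbon-only groups, 4-methylphenyl and naphthalen-2-yl, lie within the scatter of each other, while the one group with a ring nitrogen and a hydrogen-bond acceptor gives the lowest number, so less of compound 3 is tolerated. No measurement shown here explains this shift.

The compounds shown leave open whether the ring nitrogen or the loss of the methyl matters more, a question that plain phenyl would separate. They also leave open whether pyridin-4-yl or pyridin-2-yl would behave like pyridin-3-yl.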